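The source may report more compounds than this note shows. Statements on the series, on what has been measured and on what is new or still open speak of the compounds shown alone.

In a functional assay on MCF7 cells (Homo sapiens) for inhibition, read by MTT assay, with a stated time of 48 h (a lower number here means a stronger inhibitor, a higher number a weaker inhibitor), compound 1 (`CCOC(=O)C1=C(N/C=N/c2cccnc2Cl)Nc2[nH]nc(C)c2C1c1ccc(N(C)C)cc1`) gives 4180 nM and compound 3 (`CCOC(=O)C1=C(N/C=N/c2nnc(S(N)(=O)=O)s2)Nc2[nH]nc(C)c2C1c1ccc(N(C)C)cc1`) gives 34500 nM, the higher of these two numbers. Compound 2 (`CCOC(=O)C1=C(N/N=C(\c2ccc([N+](=O)[O-])cc2)N2CCN(c3ccc(F)cc3)CC2)Nc2[nH]nc(C)c2C1c1ccc(N(C)C)cc1`) reads > 100000 nM, which is a limit of the assay. Compound 4 (`CCOC(=O)C1=C(N/N=C(/C(=O)Br)c2ccc(Br)cc2)Nc2[nH]nc(C)c2C1c1ccc(N(C)C)cc1`) departs from compound 3 on the amine nitrogen: a group of 12 heavy atoms (8 carbon, 1 nitrogen, 1 oxygen, 2 bromine; one six-membered aromatic ring of carbon only) in place of a group of 11 heavy atoms (3 carbon, 4 nitrogen, 2 oxygen, 2 sulfur; one five-membered aromatic ring with 3 hetero atoms), on an amine nitrogen. Among the measured compounds shown here, the one measured step at this place, an 8.3-fold higher number from compound 1 to compound 3 (0.92 log units; beyond the scatter), is modest, and it moves from a six-membered aromatic ring to the five-membered one. Compound 4 returns to a six-membered aromatic ring, so a modest step to a lower number is expected, with low confidence. The expected change is a 2.5-fold lower number from compound 3 to compound 4 (0.39 log units; beyond the scatter). For compound 4 the estimated value is 14000 nM, with an expected range of 2500 nM to 80000 nM.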

Compound 4, half-maximal inhibitory concentration: 61300 nM
Compound 4: the middle estimate sits 4.4-fold (0.64 log units) below what was measured, and the stated range covers the measured number.
By their numbers in this assay, from the lowest: compound 1; then compounds 3 and 4 (each within the scatter of the next). At a limit, above all of these: compound 2.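

At this amine nitrogen, a six-membered aromatic ring of carbon only does not restore the lower number of compound 1 in this assay (a 15-fold higher number from compound 1 to compound 4 (1.17 log units; beyond the scatter)). It also leaves no separation from the five-membered aromatic ring (a 1.8-fold higher number from compound 3 to compound 4 (0.25 log units; within the scatter)), so ring size alone does not sort these three compounds. No measured property bears on either step.

Open, from the compounds shown here alone, is how an unsubstituted phenyl ring or a carboxylic acid would read at this place. Also open, going by these compounds, is whether the chlorine of compound 1 contributes to its lower number.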